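A few compounds are considered here, and "the series" means these few. Any claim that something is new, unique, unknown or untested is made for them only; others in the source may bear on it.

Measured so far:
- compound 1, `CCOc1cc(C)c(-c2cccc(COc3ccc(S(=O)(=O)CC(=O)O)cc3)c2)c(C)c1`: 63.1 nM
- compound 2, `O=C(O)CS(=O)(=O)c1ccc(OCc2cccc(-c3ccccc3)c2)cc1`: 288 nM

Both were tested in a functional assay on CHO cells for agonist activity at Free fatty acid receptor 1 (Homo sapiens), read by FLIPR and calcium flux; a higher number here means that more compound is needed for the effect, a lower number that less compound is needed. Compound 1 gives 63.1 nM, and compound 2 gives 288 nM, the higher of the two numbers; the gap between them is beyond the usual scatter, so compound 2 needs more compound for the same effect. For the measured compounds named here, no single-point step between these two has been worked out, so their values are only compared, not explained.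

Compound 3, `O=C(O)CS(=O)(=O)c1ccc(OCc2cccc(Oc3ccccc3)c2)cc1`, is not yet measured. It differs from compound 2 by phenoxy in place of phenyl on an aromatic carbon. With nothing else in the set showing what this exchange does, the expectation is cautious: the step from compound 2 to compound 3 in this assay is expected to be a 1.4-fold lower number from compound 2 to compound 3 (0.16 log units; within the scatter), small and within or near the scatter. Compound 3 is therefore estimated at 200 nM, with a likely range from 70 nM to 600 nM.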

Compound 3, half-maximal effective concentration: 97.7 nM
Beside the measured number, compound 3's estimate is 2.0-fold (0.31 log units) above it; low and high end bracket the measured number.
By their numbers in this assay, from the lowest: compounds 1 and 3 (each within the scatter of the next); then compound 2.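

In this assay, putting phenoxy in place of phenyl on an aromatic carbon, meta to a large group, gives a 2.9-fold lower number from compound 2 to compound 3 (0.47 log units; beyond the scatter), a modest step but one beyond the scatter. The change adds just one heavy atom, an oxygen that counts as a hydrogen-bond acceptor, and the ring of carbon stays the same, so even a small edit at this position can move the number. Nothing measured here explains the drop.

From the compounds shown here alone, whether the oxygen itself matters or simply the longer link remains open: a benzyl group would put a carbon where the oxygen stands, and a phenylamino group would put a nitrogen there. For the compounds shown here, only one pair of compounds shows this step, so whether it would hold on the core of compound 1 is also open.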